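The compounds below may be only part of what the source reports. "The series", "measured", "known", "first", "only" and "open" are said of these compounds alone.

Among the compounds with values here, compound 1 `COc1ccc(CN(C(=O)C=C(C)C)c2cc(OC)c(OC)c(OC)c2)cc1O` is the stronger of the two compounds measured so far. In a functional assay on KYSE-450 cells (Homo sapiens) for inhibition, read by MTT assay, with a stated time of 48 h (a higher number here means a weaker inhibitor, a lower number a stronger inhibitor), compound 1 gives 280 nM. Within the data shown here, the only other measured compound, compound 2 `C/C=C/C(=O)N(Cc1ccc(OC)c(F)c1)c1cc(OC)c(OC)c(OC)c1`, lies well behind: in this assay compound 2 gives 1400 nM, a gap that is beyond the usual scatter, so compound 1 stands lowest of the two numbers. Among the measured compounds shown here, the two measured compounds differ in more than one place, so no single structural step has yet been tied to a measured change, and nothing shows how the group on the amide's carbonyl carbon alone moves the number.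

Compound 3 `COc1ccc(CN(C(=O)C2CC2)c2cc(OC)c(OC)c(OC)c2)cc1O` keeps everything in compound 1 except that group: cyclopropyl in place of 2-methylprop-1-en-1-yl on a carbonyl carbon. For the measured compounds named here, both groups are small, carbon-only and carry no hydrogen-bond donors or acceptors, and no measured step supports a large effect either way. The expected change from compound 1 to compound 3 is therefore modest, a 1.4-fold higher number from compound 1 to compound 3 (0.15 log units; within the scatter), leaning only slightly toward a weaker inhibitor. Compound 3 is thus estimated at 400 nM, with a likely range from 150 nM to 1200 nM.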

Compound 3, half-maximal inhibitory concentration: 80 nM
Estimate against measurement, compound 3: 5.0-fold (0.70 log units) above; measured number outside the range, below it.
By their numbers in this assay, from the lowest: compound 3; then compound 1; then compound 2.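

Within the data shown here, this is the first step that changes only one place, and it shows that the group on the carbonyl carbon of the amide matters in this assay: cyclopropyl in place of 2-methylprop-1-en-1-yl gives a 3.5-fold lower number from compound 1 to compound 3 (0.54 log units; beyond the scatter) and so a stronger inhibitor. Both groups are carbon-only and carry no hydrogen-bond donors or acceptors, yet the step lies beyond the usual scatter, so exchanging one small carbon-only group for another at this position is enough to move the number. No measurement at hand explains the gain, so the step stands as an observation without a stated cause.

The compounds shown leave open whether the ring itself counts or only the loss of the double bond outside it, and an isopropyl group, a cyclobutyl ring or a longer chain on the same carbonyl carbon would help separate the two. Also open, from the compounds shown here alone, are how a group carrying an amine would behave at this position and whether the same exchange gives a similar step when the rest of the molecule is different, as it is in compound 2.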